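Moving the Methoxyphenyl Group Along a Chain-Linked Series

A few compounds are considered here, and "the series" means these few. Any claim that something is new, unique, unknown or untested is made for them only; others in the source may bear on it.

Measured in an ADME assay on HEK293 cells (Homo sapiens) for inhibition, read by MTT assay, with a stated time of 3 days; a higher number here means a weaker inhibitor, a lower number a stronger inhibitor:
- Compound 1 `COc1ccccc1/C=C/CCCOc1cc(/C=C\c2cc(OC)c(OC)c(OC)c2)ccc1OC`: > 400000 nM (a limit)
- Compound 2 `COc1cccc(/C=C/CCCOc2cc(/C=C\c3cc(OC)c(OC)c(OC)c3)ccc2OC)c1`: 39000 nM
- Compound 3 `COc1ccc(/C=C/CCCOc2cc(/C=C\c3cc(OC)c(OC)c(OC)c3)ccc2OC)cc1`: 88000 nM

Compound 3 holds the higher of the two actual numbers, with a 2.3-fold higher number from compound 2 to compound 3 (0.35 log units; beyond the scatter). Compound 1 is reported only as a limit, > 400000 nM.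

Compound 4 `COCOc1ccccc1/C=C/CCCOc1cc(/C=C\c2cc(OC)c(OC)c(OC)c2)ccc1OC` carries 2-(methoxymethoxy)phenyl in place of the 4-methoxyphenyl of compound 3, on a double-bonded chain carbon bound to a double-bonded chain carbon: 2-(methoxymethoxy)phenyl in place of 4-methoxyphenyl on a double-bonded chain carbon bound to a double-bonded chain carbon. For the measured compounds named here, no measured compound carries this group. The nearest one is the 2-methoxyphenyl of compound 1, so the most relevant steps are an at least 4.5-fold lower number from compound 1 to compound 3 (0.65 log units; beyond the scatter), which is at least modest, and an at least 10-fold lower number from compound 1 to compound 2 (1.01 log units; beyond the scatter), which is large. Run in reverse, the first of these points to a weaker inhibitor in this assay. A higher number is therefore expected, a 2.2-fold higher number from compound 3 to compound 4 (0.33 log units; beyond the scatter), of modest to large size. For compound 4 the estimated value is 190000 nM, with an expected range of 70000 nM to 400000 nM.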

Compound 4, half-maximal inhibitory concentration: 106000 nM
Compound 4: the middle estimate sits 1.8-fold (0.25 log units) above what was measured; low and high end bracket the measured number.
By their numbers in this assay, from the lowest: compound 2; then compounds 3 and 4 (each within the scatter of the next). At a limit, above all of these: compound 1.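

In this assay, the 2-(methoxymethoxy)phenyl group of compound 4 cannot be told apart from the 4-methoxyphenyl group of compound 3, a 1.2-fold higher number from compound 3 to compound 4 (0.08 log units; within the scatter), while the 3-methoxyphenyl group of compound 2 keeps its edge, a 2.7-fold higher number from compound 2 to compound 4 (0.43 log units; beyond the scatter). The methoxy added on the saturated chain carbon gives an at least 3.7-fold lower number from compound 1 to compound 4 (0.57 log units; beyond the scatter), so among these compounds a 2-substituted phenyl ring does not by itself go with the weakest reading. From the compounds shown here alone, compound 1 is reported only as a limit, so the true size of that step stays unknown: the limit of > 400000 nM in this assay, at which 1 of the 4 values shown sits.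

The compounds shown leave open how much of this recovery depends on the methoxymethoxy group as such. A hydroxy group or a dimethylamino group in its place could show whether the number moves towards that of compound 2 or back towards the limit.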